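Growth inhibition series: 4-bromophenyl to 3-bromophenyl

The source may hold more compounds than are shown below. What is called first, only, known or untested is meant among the compounds shown, and "the series" means these compounds.

Measured so far in a functional assay on T47D cells (Homo sapiens) for inhibition, read by CCK-8 assay, with a stated time of 72 h, tested at 1 uM (a lower number here means less inhibition of growth, a higher number more inhibition of growth at the concentration tested), as read-out:
- compound 1 `CN(C)C(=O)c1cc2cnc(Nc3ccc(NC(=O)C4(C(=O)Nc5cccc(F)c5)CC4)cc3)nc2n1C1CCCC1` gives -3.2% 
- compound 2 `COc1ccc(NC(=O)C2(C(=O)Nc3ccc(Nc4ncc5cc(C(=O)N(C)C)n(C6CCCC6)c5n4)cc3)CC2)cc1` gives 76.4% 
- compound 3 `CN(C)C(=O)c1cc2cnc(Nc3ccc(NC(=O)C4(C(=O)Nc5ccc(Br)cc5)CC4)cc3)nc2n1C1CCCC1` gives 21.1% 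

Compound 3 holds the middle place among the three values, with one step on each side of it (a number 24.3 percentage points higher from compound 1 to compound 3 (beyond the scatter)) and (a number 55.3 percentage points lower from compound 2 to compound 3 (beyond the scatter)). The next compound is compound 4 `CN(C)C(=O)c1cc2cnc(Nc3ccc(NC(=O)C4(C(=O)Nc5cccc(Br)c5)CC4)cc3)nc2n1C1CCCC1` which has 3-bromophenyl in place of 4-bromophenyl on an amide-type nitrogen. Within the data shown here, no measured step makes this exchange directly, so the evidence is indirect. The step (a number 79.6 percentage points higher from compound 1 to compound 2 (beyond the scatter)) shows that a change of group on this nitrogen can move the read-out widely in this small set. The closer guide is the modest step (a number 24.3 percentage points higher from compound 1 to compound 3 (beyond the scatter)), which joins the two measured compounds carrying a halogen on that phenyl. Among the measured compounds shown here, compound 1 is the only measured compound with a group named at the 3 position, and its value of -3.2% leans the expectation downward. A small drop in this assay is therefore expected, possibly none beyond the scatter. The expected step is small (a number 9.1 percentage points lower from compound 3 to compound 4 (within the scatter)). For compound 4 the estimated value is 12% with -10% as the expected lower end and 40% as the expected upper end.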

Compound 4, percent growth inhibition at one concentration: 29.1%
The estimate for compound 4 lay 17.1 percentage points below the measured number; the range from low to high includes it.
By their numbers in this assay, from the lowest: compound 1; then compounds 3 and 4 (each within the scatter of the next); then compound 2.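

In this assay, moving the bromo from 4-bromophenyl to 3-bromophenyl on the amide-type nitrogen gives a number 8 percentage points higher from compound 3 to compound 4 (within the scatter), so the two bromophenyl isomers are not separated in this assay. With the ring pattern of compound 1 kept, bromo in place of fluoro on an aromatic carbon gives a number 32.3 percentage points higher from compound 1 to compound 4 (beyond the scatter), which shows that the identity of the halogen changes the read-out here while the move of the bromo in the isomer pair does not. The exchange of 4-methoxyphenyl for 3-bromophenyl gives a number 47.3 percentage points lower from compound 2 to compound 4 (beyond the scatter), so among the four compounds, compound 2 stays well apart from both bromophenyl compounds, and the choice of group on this nitrogen counts for more than the place of the bromo.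

Nothing at hand explains why these values differ. Still open, as far as these compounds go, is whether a methoxy group in the place held by the bromo of compound 4 would keep the level of compound 2, and whether an amine or a carboxylic acid in place of that methoxy would do the same in this assay.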